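The source may hold more compounds than are shown below. What is called first, only, known or untested is meant among the compounds shown, and "the series" means these compounds.

Compound 1 `Oc1ccc(-c2cc(-c3cccs3)nc(-c3ccccc3Cl)c2)cc1`: 5430 nM
Compound 2 `Oc1ccc(-c2cc(-c3ccc(Cl)cc3)nc(-c3cccs3)c2)cc1`: 6470 nM
Compound 3 `Oc1ccc(-c2cc(-c3cccc(Cl)c3)nc(-c3cccs3)c2)cc1`: 5050 nM

All three numbers come from a functional assay on HCT-15 cells (Homo sapiens) for cytotoxicity, read by CCK-8 assay and cell counting, with a stated time of 2 days; on this read-out lower numbers stand for stronger inhibition and higher numbers for weaker inhibition. Compound 3 has the lowest of the three numbers, but its neighbours sit close: the step of a 1.1-fold lower number from compound 1 to compound 3 (0.03 log units; within the scatter) and the step of a 1.3-fold lower number from compound 2 to compound 3 (0.11 log units; within the scatter) both lie within the scatter, as does the step of a 1.2-fold higher number from compound 1 to compound 2 (0.08 log units; within the scatter), so none of the three can be called the most potent. Compound 4 `Oc1ccc(-c2cc(-c3ccccc3)nc(-c3cccc(Cl)c3)c2)cc1` keeps the core of compound 3 and changes it at one place: phenyl in place of thiophen-2-yl on an aromatic carbon. Among the compounds with values here, none of the measured steps touches this group; each of them exchanged one chlorophenyl for another, and each stayed within the scatter. Within the data shown here, there is thus no measured guide for the swap of thiophen-2-yl for phenyl, and the only anchor is that the three known numbers lie close together. The step from compound 3 to compound 4 is expected to be a 1.0-fold lower number from compound 3 to compound 4 (0.00 log units; within the scatter), with no direction beyond the scatter. Compound 4 is estimated at 5000 nM, with a range from 2500 nM to 10000 nM.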

Compound 4, half-maximal inhibitory concentration: 6100 nM
Compound 4: middle estimate off by 1.2-fold (0.09 log units), on the low side, within the range that was stated.
By their numbers in this assay, from the lowest: compounds 3, 1, 4 and 2 (each within the scatter of the next).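

Within the data shown here, until this point, the measured steps had exchanged only one chlorophenyl group for another, leaving the thiophen-2-yl group next to the ring nitrogen untested. In this assay the replacement of that five-membered aromatic ring by phenyl, a six-membered aromatic ring of carbon only, gives a 1.2-fold higher number from compound 3 to compound 4 (0.08 log units; within the scatter) and so stays within the scatter. At this position the two rings cannot be told apart in this assay, and no other measurement here speaks to the reason.

The compounds shown carry only aromatic rings at this position, so it remains open whether an amine, a carboxylic acid or a longer chain there would shift the number beyond the scatter. From the compounds shown here alone, the 4-hydroxyphenyl group is common to all four compounds, so the effect of a methoxy group in place of its hydroxyl is equally open.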